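A few compounds are considered here, and "the series" means these few. Any claim that something is new, unique, unknown or untested is made for them only; others in the source may bear on it.

Measured so far on an assay on microsomes from liver for inhibition of acyl-CoA desaturase 1 (Rattus norvegicus); on this read-out lower numbers stand for stronger inhibition and higher numbers for weaker inhibition:
compound 1 `Cc1nnc(-c2ccc(N3CCC(Oc4ccccc4C(F)(F)F)CC3)nn2)s1` gives 2.3 nM;
compound 2 `CC(C)c1nnc(-c2ccc(N3CCC(Oc4ccccc4C(F)(F)F)CC3)nn2)s1` gives 8.8 nM;
compound 3 `CC(C)Cc1nnc(-c2ccc(N3CCC(Oc4ccccc4C(F)(F)F)CC3)nn2)o1` gives 15 nM.

Compound 3 thus stands at the highest number of the three: the gap a 1.7-fold higher number from compound 2 to compound 3 (0.23 log units; within the scatter) is within the scatter, while a 6.5-fold higher number from compound 1 to compound 3 (0.81 log units; beyond the scatter) is beyond it. Compound 4 `CC(C)Cc1nnc(-c2ccc(N3CCC(Oc4ccccc4C(F)(F)F)CC3)nn2)s1` differs from compound 3 by 5-isobutyl-1,3,4-thiadiazol-2-yl in place of 5-isobutyl-1,3,4-oxadiazol-2-yl on an aromatic carbon. Among the compounds with values here, no measured step isolates this ring swap; a 6.5-fold higher number from compound 1 to compound 3 (0.81 log units; beyond the scatter) and a 1.7-fold higher number from compound 2 to compound 3 (0.23 log units; within the scatter) each combine it with a change of chain, and the nearer one is within the scatter. The step of a 2.5-fold lower number from compound 3 to compound 4 (0.40 log units; beyond the scatter) is therefore expected to be small, toward a lower number if anything. Compound 4 is estimated at 6 nM, within a range from 2.5 nM to 15 nM.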

Compound 4, half-maximal inhibitory concentration: 37 nM
Beside the measured number, compound 4's estimate is 6.2-fold (0.79 log units) below it; the whole stated range lies below it.
By their numbers in this assay, from the lowest: compound 1; then compounds 2 and 3 (each within the scatter of the next); then compound 4.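

In this assay, within the data shown here, the ring swap stands alone for the first time: with the isobutyl chain held fixed, the thiadiazole carries the higher number, a 2.5-fold higher number from compound 3 to compound 4 (0.39 log units; beyond the scatter). On the thiadiazole, the number keeps rising as the chain grows from isopropyl to isobutyl, a 4.2-fold higher number from compound 2 to compound 4 (0.62 log units; beyond the scatter), and the whole change from methyl amounts to a 16-fold higher number from compound 1 to compound 4 (1.21 log units; beyond the scatter).

On these data alone, whether the ring swap runs the same way with methyl or isopropyl on the ring remains open, as does how an amine or a carboxylic acid would read at this position. Nothing available explains the direction of the ring swap.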